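The source may hold more compounds than are shown below. What is called first, only, known or untested is meant among the compounds shown, and "the series" means these compounds.

Measured so far:
compound 1 `COc1ccc(Nc2nc3ccccc3nc2S(=O)(=O)c2ccccc2)cc1` — 640 nM
compound 2 `COc1cc(Nc2nc3ccccc3nc2S(=O)(=O)c2ccccc2)cc(OC)c1` — 50 nM

In a functional assay on HL-60 cells (Homo sapiens) for cytotoxicity, read by MTT assay, with a stated time of 72 h (on this read-out lower numbers stand for stronger inhibition and higher numbers for weaker inhibition), compound 2 holds the lowest of the two numbers, with compound 1 the nearest. Compound 3 `O=S(=O)(c1ccccc1)c1nc2ccccc2nc1Nc1ccc(C(F)(F)F)cc1` is not yet measured; it differs from compound 2 by 4-(trifluoromethyl)phenyl in place of 3,5-dimethoxyphenyl on a nitrogen on an aromatic ring. For the measured compounds named here, the one measured step, a 13-fold lower number from compound 1 to compound 2 (1.11 log units; beyond the scatter), shows that changing the groups on this same ring moves the number strongly. Compound 3 again changes that ring, so a step beyond the scatter is expected, and because compound 2 sits at 50 nM a higher number is the more likely direction. Compound 3 is estimated at 500 nM, within 120 nM to 2500 nM. That expectation corresponds to a 10-fold higher number from compound 2 to compound 3 (1.00 log units; beyond the scatter).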

Compound 3, half-maximal inhibitory concentration: 300 nM
Estimate against measurement, compound 3: 1.7-fold (0.22 log units) above; the range from low to high includes it.
By their numbers in this assay, from the lowest: compound 2; then compound 3; then compound 1.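

In this assay, trifluoromethyl in place of methoxy on an aromatic carbon gives a 2.1-fold lower number from compound 1 to compound 3 (0.33 log units; beyond the scatter), so a ring with 0 hydrogen-bond acceptors can still improve on the methoxy ring. It does not match the 3,5-dimethoxyphenyl group, though, as the change to 4-(trifluoromethyl)phenyl gives a 6.0-fold higher number from compound 2 to compound 3 (0.78 log units; beyond the scatter). Nothing available explains either step. As far as these compounds go, it remains open how an amine or a carboxylic acid in place of methoxy or trifluoromethyl would read, and whether the number follows the kind of group or how many groups the ring carries.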